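Bromo for Chloro on the Sulfonyl Phenyl Ring

This account rests on a few compounds, and the source may have more. Where it says the series, first, only, none or still open, it means among the compounds named here.

Four closely related compounds were examined for antiproliferative activity in a functional assay on A549 cells (Homo sapiens) for antiproliferative activity, read by MTT assay, with a stated time of 24 h; on this read-out higher numbers stand for weaker inhibition and lower numbers for stronger inhibition. Compound 1 `Cc1ccc(-c2nn(-c3ccccc3)cc2-c2nc3ccccc3n2S(=O)(=O)c2ccc(Cl)cc2)cc1` gives 3550 nM in this assay, and compound 2 `Cc1ccc(-c2nn(-c3ccccc3)cc2-c2nc3ccccc3n2S(=O)(=O)c2ccc(Br)cc2)cc1` gives 1860 nM. The change between them is bromo in place of chloro on an aromatic carbon, and it made a step of a 1.9-fold lower number from compound 1 to compound 2 (0.28 log units; within the scatter). Compound 3 `O=S(=O)(c1ccc(Cl)cc1)n1c(-c2cn(-c3ccccc3)nc2-c2ccc(F)cc2)nc2ccccc21` carries a different core: the difference from compound 1 is fluoro in place of methyl on an aromatic carbon, with the step of a 1.1-fold lower number from compound 1 to compound 3 (0.05 log units; within the scatter). In this assay compound 3 gives 3170 nM. Compound 4 `O=S(=O)(c1ccc(Br)cc1)n1c(-c2cn(-c3ccccc3)nc2-c2ccc(F)cc2)nc2ccccc21` has not yet been measured. It differs from compound 3 by bromo in place of chloro on an aromatic carbon, the same change that separates compound 1 from compound 2, at a place described in the same words. Because the measured pair gave a 1.9-fold lower number from compound 1 to compound 2 (0.28 log units; within the scatter), a step of similar size is expected in this assay. Compound 4 is therefore expected to show a 1.8-fold lower number from compound 3 to compound 4 (0.25 log units; within the scatter). Compound 4 is estimated at 1800 nM in this assay, with a range from 900 nM to 3600 nM. Within the data shown here, only one earlier example of this change is available, and that step lay within the scatter, so the expectation is loosely held.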

Compound 4, half-maximal inhibitory concentration: 1720 nM
The estimate for compound 4 lay 1.0-fold (0.02 log units) above the measured number; low and high end bracket the measured number.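

In this assay, bromo in place of chloro gave a 1.8-fold lower number from compound 3 to compound 4 (0.27 log units; within the scatter), a step that agrees with the earlier one on the methyl-bearing core: the same change on two cores in this assay, a 1.9-fold lower number (0.28 log units; within the scatter) from compound 1 to compound 2 and a 1.8-fold lower number (0.27 log units; within the scatter) from compound 3 to compound 4, 1.0-fold (0.02 log units) apart, within the scatter of two such steps Fluoro in place of methyl, read with bromo in place of chloro, gave a 1.1-fold lower number from compound 2 to compound 4 (0.03 log units; within the scatter), which likewise agrees with its earlier counterpart: the same change on two cores in this assay, a 1.1-fold lower number (0.05 log units; within the scatter) from compound 1 to compound 3 and a 1.1-fold lower number (0.03 log units; within the scatter) from compound 2 to compound 4, 1.0-fold (0.02 log units) apart, within the scatter of two such steps Each change therefore carried from one core to the other with a step of like size, but all four steps lie within the scatter, so this agreement does not establish a real effect of either change, and two cores cannot show that it holds across the series.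

The compounds shown leave open whether an amine or a carboxylic acid in place of the chloro or bromo would give a step beyond the scatter. They also leave open whether bromo in place of chloro would behave the same way on a core with a longer chain in place of the methyl.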